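The source may report more compounds than this note shows. Statements on the series, on what has been measured and on what is new or still open speak of the compounds shown alone.

Measured compounds:
compound 1, `NC(=O)c1sc2ccccc2c1O`: > 100000 nM
compound 2, `NC(=O)c1sc2nc(-c3ccc4c(c3)OCCO4)cc(C(F)(F)F)c2c1N`: 1300 nM
compound 3, `NNC(=O)c1sc2ncccc2c1N`: > 100000 nM

In an assay on isolated protein for inhibition of LIM domain kinase 1 (Homo sapiens), read by Kinase-Glo, with a stated time of 60 min (on this read-out higher numbers stand for weaker inhibition and lower numbers for stronger inhibition), compound 1 gives > 100000 nM, which is a limit of the assay and not a number. Compound 3 gives > 100000 nM, also a limit. For the measured compounds named here, compound 2 gives 1300 nM, the only value of the three that is a number. Compound 1 therefore stands at the limit of > 100000 nM in this assay, at which 2 of the 3 values shown sit, and no number for it is known.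

The unmeasured compound 4, `NC(=O)c1cc2ccccc2s1`, differs from compound 1 in one place: hydrogen in place of hydroxy on an aromatic carbon. Going by the values given here, no step between measured compounds is available to guide the size of this change. Compound 4 is nevertheless expected to stay at the limit as well, the expected step being a step that the limit leaves unreadable from compound 1 to compound 4. For compound 4 the estimate is 150000 nM, within 30000 nM to 500000 nM.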

Compound 4, half-maximal inhibitory concentration: > 100000 nM
Compound 4: no number, only a limit (the forecaster's own chance of this, stated with the estimate: 85%); the middle value lies beyond the limit too.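

For the compounds shown here, compound 1 and compound 4 each give only a limit and not a number, so no step between them can be read. The compounds shown leave open whether hydrogen in place of hydroxy on an aromatic carbon changes inhibition at all.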